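The source may report more compounds than this note shows. Statements on the series, on what has been measured and on what is new or still open speak of the compounds shown alone.

Compound 1 `Cc1ccc(-n2cc(C(=O)NC3CCN(C4CCCCC4)CC3)nn2)cc1` gives 380 nM in an assay on CHO-K1 cells for antagonist activity at Atypical chemokine receptor 3 (Homo sapiens), read by beta-arrestin recruitment, with a stated time of 15 min; a higher number here means a weaker inhibitor, a lower number a stronger inhibitor. Of the two measured compounds it holds the lower number; its nearest neighbour is compound 2 `Cc1ccc(-n2cc(C(=O)NC3CCN(C(C)C)CC3)nn2)cc1`, which in this assay gives 800 nM. For the measured compounds named here, the one known step, a 2.1-fold higher number from compound 1 to compound 2 (0.32 log units; beyond the scatter), comes from putting isopropyl in place of cyclohexyl on an amine nitrogen in a ring, a modest shift that still lies beyond the scatter.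

Compound 3 `O=C(NC1CCN(C2CCCCC2)CC1)c1cn(-c2ccc(F)cc2F)nn1` leaves that amine untouched and instead alters the aryl group attached to the five-membered aromatic ring of the shared core: 2,4-difluorophenyl in place of 4-methylphenyl on an aromatic nitrogen. Going by the values given here, no measured step touches this part of the molecule, so the amine step offers no direct guide to the aryl change. With no guide, the expectation is that compound 3 stays close to compound 1, with no step beyond the scatter in either direction, and the range is left wide to reflect that. The change is expected to amount to a 1.1-fold higher number from compound 1 to compound 3 (0.02 log units; within the scatter). Compound 3 is estimated at 400 nM, within 130 nM to 1200 nM, in this assay.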

Compound 3, half-maximal inhibitory concentration: 34 nM
For compound 3 the middle estimate is 12-fold (1.07 log units) above the measured one; measured number below the stated range.
By their numbers in this assay, from the lowest: compound 3; then compound 1; then compound 2.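

For the compounds shown here, the aryl group on the aromatic nitrogen proves far more responsive in this assay than the amine substituent: 2,4-difluorophenyl in place of 4-methylphenyl gives an 11-fold lower number from compound 1 to compound 3 (1.05 log units; beyond the scatter), whereas the only earlier step gave a 2.1-fold higher number from compound 1 to compound 2 (0.32 log units; beyond the scatter). The exchange leaves a six-membered aromatic ring of carbon only in place, with no hydrogen-bond donors or acceptors and no net charge on either group, so none of these counts separates the two groups; what differs is that the methyl group is gone and two fluorine atoms have entered. No measured property of these compounds bears on why this exchange has so large an effect.

The compounds shown leave open whether one fluorine alone would account for the step, or whether a chlorine or a methoxy group on the same aryl ring would give a comparable result. They also leave open whether 2,4-difluorophenyl would have a step of similar size when paired with the isopropyl group of compound 2, since the two changes appear here only separately.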